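Thiophene substituent series: cytotoxicity notes toward compound 3

The source may report more compounds than this note shows. Statements on the series, on what has been measured and on what is new or still open speak of the compounds shown alone.

Within the data shown here, compound 2 `C=Cc1csc(CN[C@@H]2C[C@H]3C[C@@H]([C@H]2C)C3(C)C)c1` gives 6250 nM in an ADME assay on MDCK cells (Canis lupus familiaris) for cytotoxicity, read by microscopy, with a stated time of 48 h (on this read-out lower numbers stand for higher toxicity in this test and higher numbers for lower toxicity in this test), the lowest of the two numbers so far; compound 1 `C[C@H]1[C@H](NCc2cc(C3CC3)cs2)C[C@H]2C[C@@H]1C2(C)C` gives 25000 nM. Among the measured compounds shown here, the one measured step, vinyl in place of cyclopropyl on an aromatic carbon, ran a 4.0-fold lower number from compound 1 to compound 2 (0.60 log units; beyond the scatter). Compound 3 `C[C@H]1[C@H](NCc2cc(C3CCCCC3)cs2)C[C@H]2C[C@@H]1C2(C)C` is not yet measured; it differs from compound 2 in one place: cyclohexyl in place of vinyl on an aromatic carbon. For the measured compounds named here, the only step that bears on this change is the one from compound 1 to compound 2, where a ring gave way to vinyl and the number fell; here vinyl gives way to a larger ring, so that step offers no direct guide in either direction. Going by the values given here, with only that evidence, compound 3 is expected to land near compound 2, with a step of about a 1.3-fold lower number from compound 2 to compound 3 (0.10 log units; within the scatter) and wide uncertainty. The estimate for compound 3 is 5000 nM, ranging from 1500 nM to 20000 nM.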

Compound 3, minimum cytotoxic concentration: 780 nM
Compound 3: the middle estimate sits 6.4-fold (0.81 log units) above what was measured; the measured number lies below the stated range.
By their numbers in this assay, from the lowest: compound 3; then compound 2; then compound 1.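

Among these compounds, the place two ring bonds from the ring sulfur proves more sensitive in this assay than the one earlier step could show: cyclohexyl in place of vinyl gives an 8.0-fold lower number from compound 2 to compound 3 (0.90 log units; beyond the scatter), and cyclohexyl in place of cyclopropyl gives a 32-fold lower number from compound 1 to compound 3 (1.51 log units; beyond the scatter). The two ring-bearing compounds therefore stand at opposite ends of the three numbers, with vinyl, which has no ring, in the middle, so the presence of a ring at this place does not by itself set the read-out. Nothing available here accounts for either step.

Three groups cannot show whether the number follows ring size, since no intermediate ring such as cyclopentyl is among them. As far as these compounds go, how a phenyl ring, a longer alkyl chain, an amine or a carboxylic acid at this place would read also remains open.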